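Benzyl for Cyclohexyl on a Weak Adenosine Receptor Ligand

This account rests on a few compounds, and the source may have more. Where it says the series, first, only, none or still open, it means among the compounds named here.

Of the compounds shown here, two with a shared core have been measured in an assay on HeLa cells for displacement of a labelled ligand from adenosine receptor A3 (Homo sapiens), read by fluorescence polarization, with a stated time of 30 min; a higher number here means a weaker inhibitor, a lower number a stronger inhibitor. Compound 1 `COc1ccc(-c2cc(NC(=O)CCC(=O)N(C)CC(=O)NCc3ccccc3)nc(-c3ccc(OC)cc3)n2)cc1` gives 35400 nM in this assay. Compound 2 `COc1ccc(-c2cc(NC(=O)CCC(=O)N3CCN(CC(=O)NC4CCCCC4)CC3)nc(-c3ccc(OC)cc3)n2)cc1` gives 35100 nM in this assay, the lower of the two numbers; compound 1 sits a hair higher, a gap that lies within the scatter, so nothing separates the two on potency. Both are weak binders.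

Compound 3 `COc1ccc(-c2cc(NC(=O)CCC(=O)N3CCN(CC(=O)NCc4ccccc4)CC3)nc(-c3ccc(OC)cc3)n2)cc1` is the next compound to be measured. It differs from compound 2 in one place: benzyl in place of cyclohexyl on an amide-type nitrogen. Going by the values given here, no measured step of this kind exists among the compounds in hand. Among the compounds with values here, the only guide is that compound 1, which also carries a benzylamide at the end of its chain, gives a number indistinguishable from that of compound 2. The step from compound 2 to compound 3 is therefore expected to be small, with no direction beyond the scatter, as expressed by a 1.1-fold lower number from compound 2 to compound 3 (0.03 log units; within the scatter). Compound 3 is accordingly estimated at 33000 nM in this assay, within a range of 14000 nM to 80000 nM.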

Compound 3, inhibition constant: 11600 nM
For compound 3 the middle estimate is 2.8-fold (0.45 log units) above the measured one; measured number below the stated range.
By their numbers in this assay, from the lowest: compound 3; then compounds 2 and 1 (each within the scatter of the next).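

In this assay, this amide-type nitrogen proves able to move the number, which the two earlier compounds could not show: benzyl in place of cyclohexyl gives a 3.0-fold lower number from compound 2 to compound 3 (0.48 log units; beyond the scatter) and so a modest step beyond the scatter. The change replaces a six-membered non-aromatic ring of carbon only with a six-membered aromatic ring of carbon only and adds one carbon, while neither group carries a hydrogen-bond donor, a hydrogen-bond acceptor or a net charge, so the step is tied to a change in the carbon group alone, though this single pair cannot separate the ring from the added carbon. Nothing available explains why the number moves at this position.

The compounds shown leave open whether the aromatic ring or the extra carbon carries the step, a question that cyclohexylmethyl or phenyl on the same nitrogen would address. On these data alone, it also remains open whether the same exchange would matter on the chain of compound 1, and whether a substituted benzyl such as methoxybenzyl would take the number further.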